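The compounds below may be only part of what the source reports. "The series", "measured", "known", "first", "only" and "open" are said of these compounds alone.

Compound 1 `CS(=O)(=O)c1cccc(C#Cc2cc(Cl)ccc2OCC(=O)O)c1` gives 15 nM in an assay on CHO cells for displacement of a labelled ligand from prostaglandin D2 receptor 2 (Homo sapiens), read by scintillation counting; on this read-out lower numbers stand for stronger inhibition and higher numbers for weaker inhibition.
Compound 2 `CS(=O)(=O)c1ccc(Cl)c(C#Cc2cc(Cl)ccc2OCC(=O)O)c1` gives 3.5 nM in this assay.

Compound 2 stands lowest of the two numbers shown; the only measured step is a 4.3-fold lower number from compound 1 to compound 2 (0.63 log units; beyond the scatter). Compound 3 `CS(=O)(=O)c1ccc(F)c(C#Cc2cc(Cl)ccc2OCC(=O)O)c1` carries fluoro in place of chloro on an aromatic carbon. That single step bears on this change, and it was modest. Because that step was a 4.3-fold lower number from compound 1 to compound 2 (0.63 log units; beyond the scatter) and compound 3 keeps only a smaller halogen at the same place, a number between those of compound 1 and compound 2 is expected, with the step of a 2.0-fold higher number from compound 2 to compound 3 (0.30 log units; within the scatter) expected toward weaker inhibition. Compound 3 is thus estimated at 7 nM, within 3 nM to 17 nM.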

Compound 3, inhibition constant: 3.3 nM
Compound 3: middle estimate off by 2.1-fold (0.33 log units), on the high side, within the range that was stated.
By their numbers in this assay, from the lowest: compounds 3 and 2 (each within the scatter of the next); then compound 1.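

In this assay, fluoro and chloro cannot be told apart at this place, para to a methylsulfonyl group (a 1.1-fold lower number from compound 2 to compound 3 (0.03 log units; within the scatter)). Fluoro also keeps the gain over hydrogen (a 4.5-fold lower number from compound 1 to compound 3 (0.66 log units; beyond the scatter)), so in these compounds that gain does not depend on chloro alone. No measurement at hand explains this result. The compounds shown leave open whether a bromo, a methoxy or a nitrile at this place would give a similar number. They also leave open how a sulfonamide in place of the methylsulfonyl group would read.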